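A few compounds are considered here, and "the series" means these few. Any claim that something is new, unique, unknown or untested is made for them only; others in the source may bear on it.

In a functional assay on NB1 cells (Homo sapiens) for cytotoxicity, read by MTT assay, with a stated time of 3 days (a higher number here means a weaker inhibitor, a lower number a stronger inhibitor), compound 1 (`N#Cc1c(O)nc(SCc2nc3ccccc3[nH]2)nc1-c1ccccc1`) gives 6.57 nM and compound 2 (`N#Cc1c(Nc2ccccn2)nc(SCc2nc3ccccc3[nH]2)nc1-c1ccccc1`) gives 3.9 nM. Among the compounds with values here, these two values lie within the scatter of each other, so compound 2 does not stand apart from compound 1 on the numbers so far.

Compound 3 (`N#Cc1c(NC(N)=S)nc(SCc2nc3ccccc3[nH]2)nc1-c1ccccc1`) has not yet been measured. Its difference from compound 2 is a group of 3 heavy atoms (1 carbon, 1 nitrogen, 1 sulfur; no ring) in place of a group of 6 heavy atoms (5 carbon, 1 nitrogen; one six-membered aromatic ring with 1 hetero atom), on a nitrogen on an aromatic ring. The group that leaves is pyridin-2-yl, and the shared core is otherwise unchanged.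

Within the data shown here, only one measured step bears on this change: a 1.7-fold lower number from compound 1 to compound 2 (0.23 log units; within the scatter). Among the measured compounds shown here, that step concerns the same substituent, but no measured compound carries the entering group, so the evidence is thin. On the basis of that single step, no shift beyond the scatter is expected in this assay, and no direction can be favoured.

The step expected is a 1.3-fold higher number from compound 2 to compound 3 (0.11 log units; within the scatter), which is an estimate that stays within the scatter. For compound 3 the estimated value is 5 nM, with an expected range of 1.5 nM to 18 nM.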

Compound 3, half-maximal inhibitory concentration: 11.9 nM
Compound 3: the middle estimate sits 2.4-fold (0.38 log units) below what was measured, and the stated range covers the measured number.
By their numbers in this assay, from the lowest: compounds 2, 1 and 3 (each within the scatter of the next, the first and the last beyond it).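

Within this assay, the change on the nitrogen on an aromatic ring gives the first step in the series that lies beyond the scatter: a 3.1-fold higher number from compound 2 to compound 3 (0.48 log units; beyond the scatter), a modest shift when pyridin-2-yl leaves and the ring-free group enters. Set against the hydroxy group on the aromatic carbon, the same entering group gives a 1.8-fold higher number from compound 1 to compound 3 (0.26 log units; within the scatter), so that substitution does not separate the two compounds. This position therefore shows a measurable difference only between the pyridin-2-yl and ring-free substituents, while the hydroxy group cannot be placed apart from either of them. No available measurement addresses the origin of the step from pyridin-2-yl to the ring-free group.

Within the data shown here, with only one ring-bearing substituent in the set, the contribution of its ring nitrogen remains open, and a phenyl group on the same nitrogen would test it directly. Also open, going by these compounds, is how a plain amine or a methoxy group on that aromatic carbon would compare with the hydroxy group and the two substituted amino groups.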